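Replacing a Methyl Ether with a Cyclohexylmethyl Ether

The source may report more compounds than this note shows. Statements on the series, on what has been measured and on what is new or still open speak of the compounds shown alone.

Compound 1 `COc1ccc2c(c1)SCC(=O)N2`: 42600 nM
Compound 2 `N#Cc1ccc(COc2ccc3c(c2)SCC(=O)N3)cc1`: 9.6 nM
Compound 3 `O=C1CSc2cc(OCc3ccc(Br)cc3)ccc2N1`: 4.1 nM

Of the compounds shown here, three sharing the same core have been tested in an assay on isolated protein for inhibition of Amine oxidase [flavin-containing] B (Homo sapiens), read by fluorescence and spectrophotometry, with a stated time of 20 min; on this read-out lower numbers stand for stronger inhibition and higher numbers for weaker inhibition. Compound 1 carries only a methoxy group on that core and gives 42600 nM, the highest of the three numbers. Compound 2 and compound 3 carry a substituted benzyloxy group in the same place instead. Compound 2 gives 9.6 nM and compound 3 gives 4.1 nM, both far below the number of compound 1. Going by the values given here, the only single-point step among the measured compounds is a 2.3-fold lower number from compound 2 to compound 3 (0.37 log units; beyond the scatter), which says little about what a larger group on the ether carbon does, since both partners already carry one.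

Compound 4 `O=C1CSc2cc(OCC3CCCCC3)ccc2N1` is the next compound to be measured. It differs from compound 1 in one place: cyclohexyl in place of hydrogen on a saturated chain carbon bound to an oxygen on an aromatic ring. The comparison of compound 1 with compound 2 and compound 3 suggests that filling this position with a ring brings a large drop in the number, though those two carry an aromatic ring and differ from compound 1 in more than one place. For compound 4 a large drop is therefore expected, a 360-fold lower number from compound 1 to compound 4 (2.55 log units; beyond the scatter), but a more cautious one than for the aromatic analogues. The estimate for compound 4 is 120 nM, with a range from 20 nM to 800 nM.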

Compound 4, half-maximal inhibitory concentration: 24 nM
For compound 4 the middle estimate is 5.0-fold (0.70 log units) above the measured one, and the stated range covers the measured number.
By their numbers in this assay, from the lowest: compound 3; then compound 2; then compound 4; then compound 1.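

In this assay, putting cyclohexyl in place of hydrogen on a saturated chain carbon bound to an oxygen on an aromatic ring gives a 1800-fold lower number from compound 1 to compound 4 (3.25 log units; beyond the scatter), so a large step at this position can now be tied to one change rather than to several at once. The group that enters is carbon only, with no hydrogen-bond donors or acceptors, which shows that a step of this size here does not require an aromatic ring, a nitrile or a bromo group. Nothing available explains why this change has such a large effect on the number.

The compounds shown leave open whether a ring is needed at all, or whether an open chain such as n-hexyl on the same carbon would give a similar step. They also leave open how the saturated ring compares with an aromatic one in a single-place change, which would take a plain phenyl group, and what a piperidine ring, with an amine in it, would do at this position.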